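A few compounds are considered here, and "the series" means these few. Any claim that something is new, unique, unknown or untested is made for them only; others in the source may bear on it.

For the measured compounds named here, compound 3 `O=C(NC(=O)c1ccc(OCc2ccccc2F)cc1)Nc1ccc(Cl)c(-c2nc3ccccc3[nH]2)c1` gives 120 nM in a functional assay on MGC-803 cells (Homo sapiens) for inhibition, read by MTT assay, with a stated time of 48 h (a higher number here means a weaker inhibitor, a lower number a stronger inhibitor), the lowest number among the three measured so far. Going by the values given here, compound 1 `Cc1ccc(NC(=O)NC(=O)c2ccc(OCc3ccccc3F)cc2)cc1-c1nc2ccccc2[nH]1` gives 2520 nM in this assay, and the single change of chloro in place of methyl on an aromatic carbon accounts for a 21-fold lower number from compound 1 to compound 3 (1.32 log units; beyond the scatter). Compound 2 `Cc1ccc(COc2ccc(C(=O)NC(=O)Nc3ccc(C)c(-c4nc5ccccc5[nH]4)c3)cc2)cc1` gives 4250 nM in this assay. Compound 4 `Cc1ccc(COc2ccc(C(=O)NC(=O)Nc3ccc(Cl)c(-c4nc5ccccc5[nH]4)c3)cc2)cc1` has not yet been measured; it differs from compound 3 in one place: 4-methylphenyl in place of 2-fluorophenyl on a saturated chain carbon bound to an oxygen on an aromatic ring. The same change has been made once before in this set, with a 1.7-fold higher number from compound 1 to compound 2 (0.23 log units; within the scatter). Among the compounds with values here, that is the only step bearing on it, and it fell within the scatter, so in this assay no step beyond the scatter is expected here either, although a slight drift toward a higher number would agree with that earlier pair. The expected step is a 1.5-fold higher number from compound 3 to compound 4 (0.18 log units; within the scatter). Compound 4 is therefore estimated at 180 nM in this assay, with a range from 70 nM to 500 nM.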

Compound 4, half-maximal inhibitory concentration: 3860 nM
Compound 4: middle estimate off by 21-fold (1.33 log units), on the low side, outside the stated range (above it).
By their numbers in this assay, from the lowest: compound 3; then compounds 1, 4 and 2 (each within the scatter of the next).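

In this assay, 4-methylphenyl in place of 2-fluorophenyl on the saturated chain carbon is far from neutral when the core carries chloro, giving a 32-fold higher number from compound 3 to compound 4 (1.51 log units; beyond the scatter), so the outcome of this change depends on the core: the same change on two cores in this assay, a 1.7-fold higher number (0.23 log units; within the scatter) from compound 1 to compound 2 and a 32-fold higher number (1.51 log units; beyond the scatter) from compound 3 to compound 4, 19-fold (1.28 log units) apart, beyond the scatter of two such steps. Chloro in place of methyl behaves the same way, and with 4-methylphenyl present it gives only a 1.1-fold lower number from compound 2 to compound 4 (0.04 log units; within the scatter), which contrasts with its large step in the 2-fluorophenyl pair: the same change on two cores in this assay, a 21-fold lower number (1.32 log units; beyond the scatter) from compound 1 to compound 3 and a 1.1-fold lower number (0.04 log units; within the scatter) from compound 2 to compound 4, 19-fold (1.28 log units) apart, beyond the scatter of two such steps. The two changes therefore do not add up, as only compound 3, with chloro and 2-fluorophenyl together, stands apart, while compounds 1, 4 and 2 each lie within the scatter of the next.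

On these data alone, it remains open how phenyl, 4-fluorophenyl or 2-methylphenyl would read on this chain carbon with chloro on the core, so the roles of the fluorine and the methyl cannot be separated. As far as these compounds go, whether bromo or methoxy in place of chloro would also pair with 2-fluorophenyl is equally open.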